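The source may hold more compounds than are shown below. What is called first, only, known or untested is meant among the compounds shown, and "the series" means these compounds.

Measured in an ADME assay on HepG2 cells (Homo sapiens) for cytotoxicity; a lower number here means that less compound is needed, a higher number that more compound is needed for the effect:
- Compound 1 `Cc1ccc(S(=O)(=O)N[C@@H](CC(=O)NC(C)(C)C)C(=O)NCCNC(=O)c2c(O)cccc2F)cc1`: > 11000 nM
- Compound 2 `Cc1ccc(S(=O)(=O)N[C@@H](CC(=O)NC(C)(C)C)C(=O)NCCNC(=O)c2cccc(C#N)c2)cc1`: > 11000 nM
- Compound 3 `Cc1ccc(S(=O)(=O)N[C@@H](CC(=O)NC(C)(C)C)C(=O)NCCNC(=O)c2cc(Cl)ccc2Cl)cc1`: > 11000 nM

Each of these entries is a limit of the assay and not a number.

Compound 3 stands at > 11000 nM, which is a limit. Among the measured compounds shown here, it has no number to rank it against the other two compounds, and the series so far is summed up by the limit of > 11000 nM in this assay, at which 3 of the 3 values shown sit.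

The next compound is compound 4 `Cc1ccc(S(=O)(=O)N[C@@H](CC(=O)NC(C)(C)C)C(=O)NCCNS(=O)(=O)c2ccccc2)cc1`. It differs from compound 3 at one place, with phenylsulfonyl in place of (2,5-dichlorophenyl)carbonyl on an amine nitrogen.

Three measured steps change the aryl group on the carbonyl carbon: a step that the two limits leave unreadable from compound 1 to compound 2, a step that the two limits leave unreadable from compound 1 to compound 3 and a step that the two limits leave unreadable from compound 2 to compound 3. The size of none of them can be read, and none replaces the carbonyl with a sulfonyl, so they bear on this change only in part. They give no sign of a shift in this assay, and no direction can be drawn from them.

The expected result is a number no higher from compound 3 to compound 4 (the limit leaves the size open), with no step beyond the scatter anticipated, given (the limit of > 11000 nM in this assay, at which 3 of the 3 values shown sit). A further limit is the most likely report.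

The estimate for compound 4 is 11000 nM, with an expected range from 6000 nM to 20000 nM.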

Compound 4, half-maximal effective concentration: > 11000 nM
Compound 4 ended at the assay's limit; the forecaster's own chance of this, stated with the estimate: 90%; the middle value sits exactly at the limit.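

In this assay compound 4 gives > 11000 nM, which is a limit and not a number. Among the compounds shown here, no step from compound 1, compound 2 or compound 3 to compound 4 can be read. The compounds shown leave open whether any change among them shifts this read-out, and what concentration any of them needs for the effect: the limit of > 11000 nM in this assay, at which 4 of the 4 values shown sit.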